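The compounds below may be only part of what the source reports. "The series", "measured", "known", "first", "only" and "open" are said of these compounds alone.

Measured so far:
Compound 1, `O=C(CCCCCCc1ccccc1)c1ncc(-c2ccccc2C(=O)C(F)(F)F)o1`: 5000 nM
Compound 2, `NC(=O)c1cccc(-c2cnc(C(=O)CCCCCCc3ccccc3)o2)c1`: 6 nM
Compound 3, `COC(=O)c1ccc(-c2cnc(C(=O)CCCCCCc3ccccc3)o2)nc1`: 3.5 nM

All three share a core bearing a long ketone chain ending in a phenyl group, and they differ only in the aromatic group attached to the five-membered ring. In an assay (Rattus norvegicus) for inhibition of Fatty-acid amide hydrolase 1 (Homo sapiens) (on this read-out higher numbers stand for weaker inhibition and lower numbers for stronger inhibition), compound 1 gives 5000 nM, by far the highest number of the three. Compound 2 gives 6 nM in this assay, the second highest number, though its nearest neighbour is compound 3 with 3.5 nM, and that gap lies within the scatter of repeated measurements, so the two cannot be told apart. The gap from compound 2 to compound 1 is far beyond the scatter.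

Compound 4, `O=C(CCCCCCc1ccccc1)c1ncc(-c2ccncn2)o1`, has not yet been measured in this assay. It differs from compound 2 in one place: pyrimidin-4-yl in place of 3-carbamoylphenyl on an aromatic carbon. For the measured compounds named here, compound 3 shows that a six-membered ring with ring nitrogen in this position is compatible with a low number, while no compound with a bare, unsubstituted ring of this kind has been measured. Compound 4 is therefore expected to land close to compound 2, with the step of a 1.2-fold lower number from compound 2 to compound 4 (0.08 log units; within the scatter) anticipated to be small and within the scatter. The estimate for compound 4 in this assay is 5 nM, with a range from 1 nM to 30 nM.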

Compound 4, inhibition constant: 2.3 nM
Beside the measured number, compound 4's estimate is 2.2-fold (0.34 log units) above it, within the range that was stated.
By their numbers in this assay, from the lowest: compounds 4, 3 and 2 (each within the scatter of the next, the first and the last beyond it); then compound 1.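

In this assay at the aromatic carbon next to the ring oxygen, pyrimidin-4-yl in place of 3-carbamoylphenyl gives a 2.6-fold lower number from compound 2 to compound 4 (0.42 log units; beyond the scatter) and so lowers the number modestly, even though the entering group is the smaller one, with 6 heavy atoms against 9 and 0 hydrogen-bond donors against 1. The earlier low numbers came only from six-membered rings that carried a further group, the carbamoyl of compound 2 and the methyl ester of compound 3, whereas compound 4 shows that a bare ring with 2 hetero atoms and no further group also gives a low number at this position. Nothing available here gives a measured reason for the size or direction of this step.

The compounds shown leave open whether a carboxylic acid, an amine or a methyl ester placed on the pyrimidin-4-yl ring itself would shift the number from that of the bare ring. They also leave open whether a plain phenyl or a pyridinyl ring at this position would give a low number, which would separate the part played by the ring nitrogens from that of the missing carbamoyl group.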